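Swapping benzoate for cinnamate on a quinoline thioether

The compounds below may be only part of what the source reports. "The series", "measured", "known", "first", "only" and "open" are said of these compounds alone.

Measured compounds:
compound 1 `CSc1cnc2ccccc2c1SCC#CCOC(=O)c1ccccc1`, 22.2 ug/mL 
compound 2 `O=C(/C=C/c1ccccc1)OCC#CCSc1cnc2ccccc2c1Cl`, 15.4 ug/mL 
compound 3 `CSc1cnc2ccccc2c1[Se]CC#CCOC(=O)c1ccccc1`, 1.9 ug/mL 

In a functional assay on CCRF-CEM cells (Homo sapiens) for antiproliferative activity, with a stated time of 72 h (on this read-out higher numbers stand for weaker inhibition and lower numbers for stronger inhibition), compound 1 gives the highest of the three numbers. Its nearest neighbour is compound 2, whose number is within the usual scatter of it, while compound 3 sits far lower, beyond the scatter. Compound 4 `CSc1cnc2ccccc2c1SCC#CCOC(=O)/C=C/c1ccccc1` is not yet measured. It differs from compound 1 in one place: 2-phenylethenyl in place of phenyl on a carbonyl carbon. Going by the values given here, no measured pair isolates this change, so the expectation rests on compound 1 alone and on compound 2, which carries the same 2-phenylethenyl ester and gives 15.4 ug/mL. The step of a 1.3-fold lower number from compound 1 to compound 4 (0.12 log units; within the scatter) is expected to be small, a slightly lower number, within the scatter. Compound 4 is therefore estimated at 17 ug/mL, with a range from 8 ug/mL to 40 ug/mL.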

Compound 4, concentration for 50% inhibition: 18.1 ug/mL
Beside the measured number, compound 4's estimate is 1.1-fold (0.03 log units) below it; low and high end bracket the measured number.
By their numbers in this assay, from the lowest: compound 3; then compounds 2, 4 and 1 (each within the scatter of the next).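

In this assay, going by these compounds alone, putting 2-phenylethenyl in place of phenyl on a carbonyl carbon gives a 1.2-fold lower number from compound 1 to compound 4 (0.09 log units; within the scatter), and this is the first pair that isolates the change. On the core of compound 1, then, this position accepts the larger group, with its double bond outside the aromatic ring, without a change beyond the scatter. Nothing measured here explains this outcome. On these data alone, it remains open whether a different kind of group at this carbonyl carbon, such as an amine, would shift the number beyond the scatter. As far as these compounds go, it is also open whether the same swap behaves alike on the core of compound 3.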